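Amino-methylpyridine in Place of Methoxypyridine on a Thiazole Acid

The source may hold more compounds than are shown below. What is called first, only, known or untested is meant among the compounds shown, and "the series" means these compounds.

Measured compounds:
compound 1 `Cc1cc(-c2nc(C(c3ccc(F)cc3)c3ccc(F)cc3)sc2CC(=O)O)ccn1` gives 3.1 nM in an in vitro assay on HEK385-7 cells for displacement of a labelled ligand from prostaglandin D2 receptor 2 (Homo sapiens); on this read-out lower numbers stand for stronger inhibition and higher numbers for weaker inhibition
compound 2 `COc1cc(-c2nc(C(c3ccc(F)cc3)c3ccc(F)cc3)sc2CC(=O)O)ccn1` gives 29 nM in this assay

Compound 2 stands at the highest of the two numbers shown; its nearest neighbour is compound 1, and the only measured step, a 9.4-fold higher number from compound 1 to compound 2 (0.97 log units; beyond the scatter), runs between them. Compound 3 `Cc1cc(-c2nc(C(c3ccc(F)cc3)c3ccc(F)cc3)sc2CC(=O)O)cnc1N` has not yet been measured. It differs from compound 2 in one place: 6-amino-5-methylpyridin-3-yl in place of 2-methoxypyridin-4-yl on an aromatic carbon. Within the data shown here, only the step from compound 1 to compound 2 bears on this change, and only in part: it shows what methoxy against methyl on the pyridine does, but says nothing about moving the point of attachment or adding an amino group. Since the methyl returns in compound 3 and the methoxy leaves, a number nearer to that of compound 1 than to that of compound 2 is expected, though the second ring change leaves the size uncertain. For compound 3 the expected step is a 2.9-fold lower number from compound 2 to compound 3 (0.46 log units; beyond the scatter). Compound 3 is therefore estimated at 10 nM, with a range from 2 nM to 50 nM.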

Compound 3, half-maximal inhibitory concentration: 880 nM
The estimate for compound 3 lay 88-fold (1.94 log units) below the measured number; measured number above the stated range.
By their numbers in this assay, from the lowest: compound 1; then compound 2; then compound 3.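

At this aromatic carbon, next to the ring nitrogen and next to the ring atom that bears the carboxymethyl group, replacing the whole pyridine group moves the number much further than exchanging methoxy for methyl did: in this assay there is a 30-fold higher number from compound 2 to compound 3 (1.48 log units; beyond the scatter), and a 280-fold higher number from compound 1 to compound 3 (2.45 log units; beyond the scatter). Methyl on the pyridine is therefore not enough to give a low number, since compound 3 carries a methyl and still has the highest number of the three, even though the entering and leaving groups are alike in heavy atoms, and the entering group adds a hydrogen-bond donor. Nothing measured here explains the loss.

As far as these compounds go, the change to compound 3 alters the point of attachment, the place of the ring nitrogen relative to it and the presence of the amino group all at once, so the share of each in the higher number remains open. A 5-methylpyridin-3-yl group, with the methyl kept and the amino group gone, and a 2-aminopyridin-4-yl group, with the amine on the attachment pattern of compound 1, would separate these contributions.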